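Series notes: benzyl substituent change toward compound 4

The compounds below may be only part of what the source reports. "The series", "measured", "known", "first", "only" and "open" are said of these compounds alone.

Compound 3 `CCN(Cc1ccccc1F)C(=O)C1CCN(S(=O)(=O)c2ccc3cn[nH]c3c2)CC1` gives 84% in a functional assay on CHO cells for positive allosteric modulation of muscarinic acetylcholine receptor M5 (Homo sapiens), read by calcium flux (on this read-out higher numbers stand for larger maximal responses and lower numbers for smaller maximal responses), the highest of the three numbers recorded so far. Compound 1 `CCN(Cc1ccccc1)C(=O)C1CCN(S(=O)(=O)c2ccccc2)CC1` gives 69% and compound 2 `CCN(Cc1ccccc1)C(=O)C1CCN(S(=O)(=O)c2ccc(OC)c(OC)c2)CC1` gives 57%; the gap from compound 3 to each of them lies beyond the scatter. Compound 4 `CCN(Cc1cccc(C(F)(F)F)c1)C(=O)C1CCN(S(=O)(=O)c2ccc3cn[nH]c3c2)CC1` has not been measured. It differs from compound 3 in a single place: 3-(trifluoromethyl)phenyl in place of 2-fluorophenyl on a saturated chain carbon bound to an amide-type nitrogen.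

For the measured compounds named here, the only step measured between neighbours that differ in one place is a number 12 percentage points lower from compound 1 to compound 2 (beyond the scatter), and that step concerns the group on the sulfonyl sulfur, not the benzyl side. Going by the values given here, compound 1 and compound 3 differ in two places at once, so their values show only that compound 3, with its 2-fluorobenzyl and its own sulfonyl aryl, reaches the larger maximal response; the two contributions cannot be separated. Among the compounds with values here, no measured step bears on the change from 2-fluorobenzyl to 3-(trifluoromethyl)benzyl, and the data give no direction for it. The step of a number 6 percentage points lower from compound 3 to compound 4 (within the scatter) is therefore expected to stay within the scatter. Compound 4 is estimated at 78%, with a range from 55% to 98%.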

Compound 4, largest response reached (reported as percent of maximum), in percent of the reference or control that the assay uses: 59%
Beside the measured number, compound 4's estimate is 19 percentage points above it; the measured number falls inside the stated range.
By their numbers in this assay, from the lowest: compounds 2, 4 and 1 (each within the scatter of the next, the first and the last beyond it); then compound 3.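

Holding the sulfonyl group of compound 3 fixed, 3-(trifluoromethyl)phenyl in place of 2-fluorophenyl on a saturated chain carbon bound to an amide-type nitrogen gives a number 25 percentage points lower from compound 3 to compound 4 (beyond the scatter) in this assay, so the benzyl side of the series has a measured effect on the largest response reached, which the comparison of compound 1 with compound 3 could not separate from the sulfonyl side. For the compounds shown here, the single step changes the substituent and also its place on the ring, taking the group from 7 to 10 heavy atoms with no hydrogen-bond donors or acceptors on either side, and the drop cannot be assigned to either part of that change. Nothing at hand accounts for the size or the direction of this step.

Open, as far as these compounds go, is how a plain benzyl, a 3-fluorobenzyl or a 2-(trifluoromethyl)benzyl would read on the sulfonyl group of compound 3, which would separate the substituent from its place on the ring. Also open, from the compounds shown here alone, is whether a methoxy or a nitrile on that benzyl ring, or a pyridine ring in place of the phenyl, would hold the response of compound 3 or lose it.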